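The source may report more compounds than this note shows. Statements on the series, on what has been measured and on what is new or still open speak of the compounds shown alone.

Three compounds carry numbers from an assay on CHO cells for displacement of a labelled ligand from transmembrane domain-containing protein TMIGD3 (Homo sapiens); on this read-out higher numbers stand for weaker inhibition and lower numbers for stronger inhibition:

Compound 1 `CC(=O)Oc1cccc2cc(-c3cc(Br)cs3)c(=O)oc12` gives 4080 nM.
Compound 2 `O=c1oc2c(O)cccc2cc1-c1cccs1` gives 1430 nM.
Compound 3 `O=c1oc2c(O)cccc2cc1-c1ccsc1` gives 2870 nM.

Compound 3 stands second highest of these three numbers, and its differences to compound 1 and to compound 2 are both within the scatter, so no order among the three can be read from them. Compound 4 `O=c1oc2c(O)cccc2cc1-c1cc(Br)cs1` is not yet measured. It differs from compound 3 in one place: 4-bromothiophen-2-yl in place of thiophen-3-yl on an aromatic carbon. Among the compounds with values here, one measured step bears on this change, the one that swapped the attachment point of the thiophene ring and gave a 2.0-fold higher number from compound 2 to compound 3 (0.30 log units; within the scatter). Within the data shown here, compound 4 reverses that swap and adds a bromine; compound 1 carries the same 4-bromothiophen-2-yl group, with an acetoxy group in place of the hydroxyl, and gives 4080 nM, but no single step connects it to compound 4. A move toward the number of compound 2 is expected, yet not beyond the scatter: the estimated step is a 1.4-fold lower number from compound 3 to compound 4 (0.16 log units; within the scatter). Compound 4 is therefore expected to give 2000 nM, within a range from 800 nM to 5000 nM.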

Compound 4, inhibition constant: 746 nM
Compound 4: the middle estimate sits 2.7-fold (0.43 log units) above what was measured, and the stated range ends above it.
By their numbers in this assay, from the lowest: compounds 4, 2, 3 and 1 (each within the scatter of the next, the first and the last beyond it).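

In this assay, within the data shown here, moving from thiophen-3-yl to 4-bromothiophen-2-yl gives a 3.8-fold lower number from compound 3 to compound 4 (0.59 log units; beyond the scatter) and is the first change at this position to pass the scatter, although it alters the attachment point and adds a bromine at once. Bromo in place of hydrogen alone gives a 1.9-fold lower number from compound 2 to compound 4 (0.28 log units; within the scatter) and stays within the scatter, as does the change of attachment point alone, so neither part on its own accounts for the combined step. At the other site, hydrogen in place of acetyl on the oxygen gives a 5.5-fold lower number from compound 1 to compound 4 (0.74 log units; beyond the scatter) with the 4-bromothiophen-2-yl group held constant, so that site also moves the number beyond the scatter.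

On these data alone, whether chloro in place of bromo, an amine or a carboxylic acid on the thiophene ring, or bromo on the thiophen-3-yl group would hold or shift the number stays open. Nothing beyond these numbers bears on why the steps have these sizes.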